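The compounds below may be only part of what the source reports. "The series", "measured", "known", "first", "only" and "open" are said of these compounds alone.

Three related compounds have been measured in a physicochemical assay for solubility; a lower number here means a less soluble compound, a higher number a more soluble compound. Compound 1 `O=C(c1ccccn1)N1CCC(NS(=O)(=O)c2cc(S(=O)(=O)c3ccccc3)ccc2C(F)(F)F)CC1` gives 100000 nM, compound 2 `CC(C)(C)OC(=O)N1CC[C@H](C(=O)N2CCC(NS(=O)(=O)c3cc(S(=O)(=O)c4ccccc4)ccc3C(F)(F)F)CC2)C1` gives 25000 nM and compound 3 `CC(C)(C)OC(=O)N1CC[C@@H](C(=O)N2CCC(NS(=O)(=O)c3cc(S(=O)(=O)c4ccccc4)ccc3C(F)(F)F)CC2)C1` gives 12500 nM. The gap of a 2.0-fold lower number from compound 2 to compound 3 (0.30 log units; within the scatter) does not separate this pair, so compound 3 stands level with compound 2, and both sit clearly under compound 1.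

Compound 4 `O=C(CC1CCNCC1)N1CCC(NS(=O)(=O)c2cc(S(=O)(=O)c3ccccc3)ccc2C(F)(F)F)CC1` differs from compound 3 at one place: (piperidin-4-yl)methyl stands in place of 1-(tert-butoxycarbonyl)pyrrolidin-3-yl on a carbonyl carbon ((piperidin-4-yl)methyl in place of 1-(tert-butoxycarbonyl)pyrrolidin-3-yl on a carbonyl carbon). The measured steps that bear on this are those in which the same 1-(tert-butoxycarbonyl)pyrrolidin-3-yl group replaces pyridin-2-yl on that carbon. They are modest: a 4.0-fold lower number from compound 1 to compound 2 (0.60 log units; beyond the scatter) and an 8.0-fold lower number from compound 1 to compound 3 (0.90 log units; beyond the scatter). Read in reverse, these two steps suggest a higher number of similar size once that group leaves, though the entering group is not pyridin-2-yl and so the guess stays loose. The estimated step is a 4.8-fold higher number from compound 3 to compound 4 (0.68 log units; beyond the scatter). For compound 4 the expected value is 60000 nM, with an estimated range from 20000 nM to 150000 nM.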

Compound 4, solubility: 100000 nM
Beside the measured number, compound 4's estimate is 1.7-fold (0.22 log units) below it, and the stated range covers the measured number.
By their numbers in this assay, from the lowest: compounds 3 and 2 (each within the scatter of the next); then compounds 1 and 4 (each within the scatter of the next).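

Putting (piperidin-4-yl)methyl in place of 1-(tert-butoxycarbonyl)pyrrolidin-3-yl on this carbonyl carbon raises the number in this assay, with an 8.0-fold higher number from compound 3 to compound 4 (0.90 log units; beyond the scatter) and a 4.0-fold higher number from compound 2 to compound 4 (0.60 log units; beyond the scatter). These two readings describe the same swap, and they can be taken together for one reason: the fact that compounds 2 and 3 differ only in the configuration as drawn. Within the data shown here, the comparison with the earlier pyridin-2-yl group shows no change at the digits printed from compound 1 to compound 4 (within the scatter), so this position holds two quite different groups at the same level, and the lower numbers so far are confined to compounds 2 and 3.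

The swap changes the ring, the tert-butoxycarbonyl group and the link to the carbonyl carbon all at once, so these compounds cannot say which part matters. A pyrrolidin-3-yl group without the tert-butoxycarbonyl, or a piperidin-4-yl group with no methyl link, would begin to pull these parts apart.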